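Relocating the Ethyl Group on the Ester of Compound 2

The compounds below may be only part of what the source reports. "The series", "measured", "known", "first", "only" and "open" are said of these compounds alone.

Compound 1 `CCc1ccc(C(=O)OCCCc2cn(-c3ccnc4cc(Cl)ccc34)nn2)cc1`: in an ADME assay on HepG2 cells (Homo sapiens) for cytotoxicity, read by MTT assay, with a stated time of 24 h (a lower number here means that less compound is tolerated, a higher number that more compound is tolerated), compound 1 gives > 2550000 nM, a limit of the assay.
Compound 2 `CCc1ccc(C(=O)OCc2cn(-c3ccnc4cc(Cl)ccc34)nn2)cc1`: in this assay compound 2 gives > 2550000 nM, again a limit.

Compound 2 therefore stands only at a limit, and both values shown sit at the limit of > 2550000 nM in this assay, at which 2 of the 2 values shown sit. Compound 3 `CCc1ccccc1C(=O)OCc1cn(-c2ccnc3cc(Cl)ccc23)nn1` differs from compound 2 by 2-ethylphenyl in place of 4-ethylphenyl on a carbonyl carbon. Within the data shown here, with no measured step to lean on, compound 3 is expected to show no change beyond the scatter, a number no higher from compound 2 to compound 3 (the limit leaves the size open). Compound 3 is estimated at 2550000 nM, between 1000000 nM and 5000000 nM, most likely reported again as a limit.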

Compound 3, half-maximal cytotoxic concentration: > 2550000 nM
Compound 3: only a limit was reported; the forecaster's own chance of this, stated with the estimate: 85%; the middle value lies on the limit itself.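

In this assay compound 3 gives > 2550000 nM, a limit of the assay. Among these compounds, compound 2 also stands at a limit, and no step between compound 2 and compound 3 can be read. The compounds shown leave open whether 2-ethylphenyl and 4-ethylphenyl differ at all in the concentration tolerated.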